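This account rests on a few compounds, and the source may have more. Where it says the series, first, only, none or still open, it means among the compounds named here.

Values in an assay on CHO cells for positive allosteric modulation of metabotropic glutamate receptor 5 (Homo sapiens), read by FLIPR (a higher number here means that more compound is needed for the effect, a lower number that less compound is needed), for the measured compounds:

compound 1 `O=C(CCc1cc(Cl)ccc1NC(=O)c1ccccn1)c1ccccc1`: 4500 nM
compound 2 `O=C(/C=C/c1cc(Cl)ccc1NC(=O)c1ccccn1)c1ccccc1`: 1700 nM
compound 3 `O=C(Nc1ccc(Cl)cc1CN1C(=O)c2ccccc2C1=O)c1cccnc1`: 35000 nM

Compound 3 gives the highest number of the three. Its gap to compound 1, the nearest, lies beyond the scatter, and its gap to compound 2, the furthest, lies further still beyond it. Among the measured compounds shown here, compound 1 and compound 2 share the core of compound 1, while compound 3 carries a different core, so no single-point step between measured compounds is available to read a trend from.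

Compound 4 `O=C(Nc1ccc(Cl)cc1CN1C(=O)c2ccccc2C1=O)c1ncccn1` keeps the core of compound 3 and differs from it in one place: pyrimidin-2-yl in place of pyridin-3-yl on a carbonyl carbon. For the measured compounds named here, no measured pair shows this exchange, so the direction of its effect is not known from the series. The change is an exchange of one six-membered aromatic ring for another of the same size on the same carbonyl carbon; the expectation for compound 4 in this assay is a step from compound 3 of a 1.2-fold lower number from compound 3 to compound 4 (0.07 log units; within the scatter), that is, none beyond the scatter. Compound 4 is therefore estimated at 30000 nM, with a range from 8000 nM to 100000 nM, and the weak starting point of compound 3 leaves a real chance that only a limit is reported.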

Compound 4, half-maximal effective concentration: 2100 nM
The estimate for compound 4 lay 14-fold (1.15 log units) above the measured number; the whole stated range lies above it.
By their numbers in this assay, from the lowest: compounds 2 and 4 (each within the scatter of the next); then compound 1; then compound 3.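

In this assay pyrimidin-2-yl in place of pyridin-3-yl on the carbonyl carbon bonded to the amide-type nitrogen gives a 17-fold lower number from compound 3 to compound 4 (1.22 log units; beyond the scatter) and shows that this position responds strongly to an exchange between two six-membered aromatic rings. The heavy-atom count stays the same while the ring hetero atoms and hydrogen-bond acceptors each rise by one, and a single step cannot show which feature of the exchange carries the effect. No measurement on these compounds accounts for the size of the step.

Open, as far as these compounds go, is how pyrazin-2-yl or pyrimidin-5-yl on the same carbonyl carbon would compare with pyrimidin-2-yl. Also open, from the compounds shown here alone, is whether pyridin-2-yl, carried by compound 1 and compound 2 on another core, would behave like pyrimidin-2-yl on the core of compound 3.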